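A few compounds are considered here, and "the series" means these few. Any claim that something is new, unique, unknown or untested is made for them only; others in the source may bear on it.

Going by the values given here, in a functional assay on the whole organism (Tail, strain ICR) with Mus musculus as the target, in the tail flick test, with a stated time of 90 min, at a dose of 25 umol/kg by the oral route (a lower number here means a weaker effect, a higher number a stronger effect of the compound at the dose given), compound 1 `O=C(CN(c1nc(Cl)nc2[nH]cnc12)C1CC1)N[C@@H](CC(=O)OCc1ccccc1)C(=O)OCc1ccccc1` gives 15.6%, the lowest of the three values known so far. Compound 3 `N=C(N)NCCC[C@H](NC(=O)CN(c1nc(Cl)nc2[nH]cnc12)C1CC1)C(=O)O` gives 27.6%, and compound 2 `O=C(OCc1ccccc1)[C@@H]1CCCN1C(=O)CN(c1nc(Cl)nc2[nH]cnc12)C1CC1` gives 43.3%; both gaps from compound 1 lie beyond the usual scatter. Compound 4 `C[C@@H](O)[C@H](NC(=O)CN(c1nc(Cl)nc2[nH]cnc12)C1CC1)C(=O)OCc1ccccc1` keeps the shared core and differs from compound 1 in one place: 1-hydroxyethyl in place of (benzyloxycarbonyl)methyl on a saturated chain carbon bound to an amide-type nitrogen and a carbonyl carbon. Among the compounds with values here, no measured pair shows a change of this kind, so the step can only be judged from the spread of the three known values, all of which lie in the weak-to-moderate range. A modest rise is expected, a number 12.4 percentage points higher from compound 1 to compound 4 (beyond the scatter). Compound 4 is therefore estimated at 28%, within a range from 10% to 48%.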

Compound 4, a percentage reported as activity, at one dose (the size of the read-out at that dose, not a potency): 29.9%
The estimate for compound 4 lay 1.9 percentage points below the measured number; the measured number falls inside the stated range.
By their numbers in this assay, from the lowest: compound 1; then compounds 3 and 4 (each within the scatter of the next); then compound 2.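

In this assay, putting 1-hydroxyethyl in place of (benzyloxycarbonyl)methyl on a saturated chain carbon bound to an amide-type nitrogen and a carbonyl carbon gives a number 14.3 percentage points higher from compound 1 to compound 4 (beyond the scatter). So at this place, the larger group with its aromatic ring is not required for the effect seen at this dose. Nothing measured here gives a reason for the rise.

This single step cannot separate losing the old group from gaining the new one. A plain ethyl or an aminomethyl group at this place would help tell those two apart.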